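A few compounds are considered here, and "the series" means these few. Any claim that something is new, unique, unknown or untested is made for them only; others in the source may bear on it.

Measured in a functional assay on HL-60 cells (Homo sapiens) for cytotoxicity, read by WST assay, with a stated time of 48 h (on this read-out higher numbers stand for weaker inhibition and lower numbers for stronger inhibition), are:
Compound 1 `COC[C@H](C(C)C)C(c1ccc(O)c(OC)c1)c1ccc(O)c(OC)c1` with 72000 nM
Compound 2 `COc1cc(C(c2ccc(O)c(OC)c2)[C@@H](C)C(C)C)ccc1O` with 20000 nM
Compound 3 `COc1cc(C(c2ccc(O)c(OC)c2)[C@H](CF)C(C)C)ccc1O` with 19000 nM

Compound 3 stands level with compound 2 (a 1.1-fold lower number from compound 2 to compound 3 (0.02 log units; within the scatter)), and both lie clear of compound 1. Compound 4 `COc1cc(C(c2ccc(O)c(OC)c2)[C@@H](C)[C@H](C)CO)ccc1O` has not yet been measured. It differs from compound 3 by 2-(hydroxymethyl)-1-methylpropyl in place of 1-(fluoromethyl)-2-methylpropyl on a saturated chain carbon bound to two aromatic carbons in a single change: 2-(hydroxymethyl)-1-methylpropyl in place of 1-(fluoromethyl)-2-methylpropyl on a saturated chain carbon bound to two aromatic carbons.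

Going by the values given here, no measured compound carries the entering group, so the evidence is indirect. Among the measured compounds, only compound 1 has oxygen in this group, and two modest steps lead away from it (a 3.6-fold lower number from compound 1 to compound 2 (0.56 log units; beyond the scatter); a 3.8-fold lower number from compound 1 to compound 3 (0.58 log units; beyond the scatter)). Going by those steps, a modest move to a higher number is expected in this assay (a 2.4-fold higher number from compound 3 to compound 4 (0.37 log units; beyond the scatter)). For compound 4 the estimated value is 45000 nM, with an expected range of 15000 nM to 120000 nM.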

Compound 4, half-maximal inhibitory concentration: > 100000 nM
Compound 4 gave a limit, no number (the forecaster's own chance of this, stated with the estimate: 10%); at least 2.2-fold (0.34 log units) between middle value and limit.
By their numbers in this assay, from the lowest: compounds 3 and 2 (each within the scatter of the next); then compound 1. At a limit, above all of these: compound 4.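

In this assay compound 4 gives > 100000 nM, which is a limit of the assay and not a number. Even so, the steps can be read against the two compounds with no oxygen in this group, an at least 5.2-fold higher number from compound 3 to compound 4 (0.72 log units; beyond the scatter) and an at least 5.0-fold higher number from compound 2 to compound 4 (0.69 log units; beyond the scatter); the second of these is the change of hydroxy in place of hydrogen on a saturated chain carbon, four bonds along the chain from two aromatic carbons, so this single change goes with weaker inhibition, whereas a 1.1-fold lower number from compound 2 to compound 3 (0.02 log units; within the scatter) goes with 1-(fluoromethyl)-2-methylpropyl in place of 1,2-dimethylpropyl. The remaining step, an at least 1.3-fold higher number from compound 1 to compound 4 (0.14 log units; that floor lies within the scatter), cannot be read, and the ceiling that limits these comparisons is this: the limit of > 100000 nM in this assay, at which 1 of the 4 values shown sits.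

As far as these compounds go, the true value of compound 4 stays open. So does whether an amine or a carboxylic acid at the same chain end would also go with weaker inhibition.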